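This account rests on a few compounds, and the source may have more. Where it says the series, first, only, none or still open, it means among the compounds named here.

Among the compounds with values here, in a functional assay on MDA-MB-231 cells (Homo sapiens) for inhibition, read by MTT assay, with a stated time of 48 h (a lower number here means a stronger inhibitor of growth, a higher number a weaker inhibitor of growth), compound 3 (`S=C(Nc1ccc(Cl)cc1)Nc1ccc2ncnc(Nc3cccc(Br)c3)c2c1`) gives 8200 nM, the only true number among the three compounds measured. Compound 1 (`S=C(NCc1ccccc1)Nc1ccc2ncnc(Nc3ccccc3Br)c2c1`) reads > 30000 nM, which is a limit of the assay and not a number. Compound 2 (`Oc1cccc(Nc2ncnc3ccc(NC(=S)NCc4ccccc4)cc23)c1`) reads > 30000 nM, which is also a limit. Compound 4 (`FC(F)(F)c1cccc(NC(=S)Nc2ccc3ncnc(Nc4cccc(Br)c4)c3c2)c1`) differs from compound 3 by one exchange: 3-(trifluoromethyl)phenyl in place of 4-chlorophenyl on an amide-type nitrogen. In short, it carries 3-(trifluoromethyl)phenyl in place of 4-chlorophenyl on an amide-type nitrogen. Within the data shown here, the only measured step is a step that the two limits leave unreadable from compound 1 to compound 2. That step has no readable size, and it concerns a different place on the molecule, so it offers no guide to this exchange. No size or direction can therefore be drawn from the data, and no change beyond the usual scatter is expected in this assay. The expectation stays anchored on compound 3 at 8200 nM. The estimated step is a 1.0-fold lower number from compound 3 to compound 4 (0.01 log units; within the scatter). For compound 4 the expected value is 8000 nM, with an estimated range of 2500 nM to 26000 nM.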

Compound 4, concentration for 50% growth inhibition: 1400 nM
The estimate for compound 4 lay 5.7-fold (0.76 log units) above the measured number; the whole stated range lies above it.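

In this assay, the group on the amide-type nitrogen whose other neighbour is the thiocarbonyl carbon proves able to move the number: 3-(trifluoromethyl)phenyl in place of 4-chlorophenyl gives a 5.9-fold lower number from compound 3 to compound 4 (0.77 log units; beyond the scatter). Within the data shown here, this modest step is the first readable effect of any change, and it shows that one aryl group can be exchanged for another here with a gain in growth inhibition. The earlier step cannot be read, as compound 1 and compound 2 each stand at a limit of the assay and not at a number: the limit of > 30000 nM in this assay, at which 2 of the 4 values shown sit.

One pair cannot tell whether the step belongs to the trifluoromethyl group or to its place on the ring, a question that 3-chlorophenyl and 4-(trifluoromethyl)phenyl would help to separate. From the compounds shown here alone, how this position would respond to an amine or a carboxylic acid on the aryl ring also remains open.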